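This account rests on a few compounds, and the source may have more. Where it says the series, first, only, none or still open, it means among the compounds named here.

Measured in an ADME assay on MRC5 cells (Homo sapiens) for inhibition, with a stated time of 72 h; on this read-out higher numbers stand for an effect only at larger amounts of compound and lower numbers for an effect already at smaller amounts:
- Compound 1 `CO[C@H]1CC[C@H](NC(=O)c2n[nH]cc2NC(=O)c2ccccc2)CC1` gives 800 nM
- Compound 2 `CO[C@H]1CC[C@H](NC(=O)c2n[nH]cc2NC(=O)c2cnc3ccccn23)CC1` gives 5900 nM
- Compound 3 `CO[C@H]1CC[C@H](NC(=O)c2n[nH]cc2NC(=O)C2CCOCC2)CC1` gives > 50000 nM

For compound 3, > 50000 nM is a limit of the assay and not a number. Compound 4 `CO[C@H]1CC[C@H](NC(=O)c2n[nH]cc2NC(=O)c2cc3ccccc3o2)CC1` carries 1-benzofuran-2-yl in place of oxan-4-yl on a carbonyl carbon. Among the compounds with values here, two measured steps bear on this change, and both are beyond the scatter: an at least 62-fold higher number from compound 1 to compound 3 (1.79 log units; beyond the scatter) when oxan-4-yl replaces phenyl, and an at least 8.4-fold higher number from compound 2 to compound 3 (0.92 log units; beyond the scatter) when oxan-4-yl replaces the two-ring aromatic group. Both steps lead towards oxan-4-yl, whereas compound 4 leaves it. The aromatic groups also differ among themselves, as a 7.4-fold higher number from compound 1 to compound 2 (0.87 log units; beyond the scatter) shows, so the range stays wide. A lower number is therefore expected in this assay, with an at least 25-fold lower number from compound 3 to compound 4 (1.39 log units; beyond the scatter) as the estimated step. Compound 4 is expected at 2000 nM, with an estimated range of 400 nM to 10000 nM.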

Compound 4, half-maximal effective concentration: 800 nM
The estimate for compound 4 lay 2.5-fold (0.40 log units) above the measured number, within the range that was stated.
By their numbers in this assay, from the lowest: compounds 1 and 4 (each within the scatter of the next); then compound 2. At a limit, above all of these: compound 3.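

In this assay, 1-benzofuran-2-yl in place of oxan-4-yl gives an at least 62-fold lower number from compound 3 to compound 4 (1.79 log units; beyond the scatter) and so adds a third aromatic group that stands clear of the saturated oxan-4-yl. Two-ring aromatic groups do not all behave alike, as a 7.4-fold lower number from compound 2 to compound 4 (0.87 log units; beyond the scatter) shows, whereas the change from phenyl gives no change at the digits printed from compound 1 to compound 4 (within the scatter) and so the second ring alone does not set the number. Compound 3 stands at a limit and not a number: the limit of > 50000 nM in this assay, at which 1 of the 4 values shown sits.

On these data alone, how an amine or a carboxylic acid would read on this carbonyl carbon stays open.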